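The compounds below may be only part of what the source reports. "The series", "measured", "known", "first", "only" and "open" are said of these compounds alone.

Compound 1 `N[C@H](C(=O)O)C(Cc1ccccc1)C(=O)O` carries a plain aromatic ring on the shared core, with nothing attached to that ring. Going by the values given here, in an in vitro assay on cells for inhibition of excitatory amino acid transporter 3 (Homo sapiens), tested at 100 uM (a lower number here means less inhibition, a higher number more inhibition at the concentration tested (going by the name of the read-out)), compound 1 gives 4%, the lowest of the three numbers measured so far. Compound 2 `N[C@H](C(=O)O)C(Cc1ccc2ccccc2c1)C(=O)O` gives 68% in this assay, and compound 3 `N[C@H](C(=O)O)C(Cc1c(Cl)cccc1Cl)C(=O)O` gives 86%; both stand far above compound 1, well beyond the usual scatter of repeated measurements.

Compound 4 `N[C@H](C(=O)O)C(Cc1cccc(Br)c1)C(=O)O` differs from compound 1 in a single place: bromo in place of hydrogen on an aromatic carbon. Among the compounds with values here, no two measured compounds differ in just one place, so the size of this particular change has not been seen directly. Within the data shown here, what the numbers do show is that compound 1, the only one with a bare ring, has the lowest number, while compound 2 and compound 3, which carry more on the aromatic ring, give far higher numbers in this assay. A rise beyond the scatter is therefore expected, though probably a smaller one than for compound 3 with its two chlorines. Compound 4 is expected to give about 35% in this assay, most likely between 10% and 65%. This estimate means an expected step of a number 31 percentage points higher from compound 1 to compound 4 (beyond the scatter), upward.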

Compound 4, a percentage reported as inhibition, at one concentration (the size of the read-out at that concentration, not a potency): 8%
For compound 4 the middle estimate is 27 percentage points above the measured one; measured number below the stated range.
By their numbers in this assay, from the lowest: compounds 1 and 4 (each within the scatter of the next); then compound 2; then compound 3.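

Putting bromo in place of hydrogen on an aromatic carbon, meta to a large group, gives a number 4 percentage points higher from compound 1 to compound 4 (within the scatter) in this assay for this pair. Going by these compounds alone, this is the first direct view of a single change on the ring, and it shows that this one bromine atom at this place does not move the number beyond the usual scatter, so compound 4 goes against any simple idea that adding to the ring raises the number. Nothing measured on these compounds explains why this change has so little effect.

Still open, on these data alone, is whether another group on this same carbon, such as methoxy, an amine or a carboxylic acid, would move the number. Also open, as far as these compounds go, is whether bromo on a different carbon of the ring would give the same result.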